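The source may report more compounds than this note shows. Statements on the series, on what has been measured and on what is new or still open speak of the compounds shown alone.

Numbers so far, all in a functional assay on N2a cells (Mus musculus), with a stated time of 48 h, tested at 0.01 uM; on this read-out lower numbers stand for a weaker effect and higher numbers for a stronger effect at the one concentration tested:
compound 1, `C#CC[C@@H]1C[C@H](n2cccc2C(C)=O)C(=O)O1`, gives 8.03%
compound 2, `C#CC[C@@H]1C[C@H](n2cccc2)C(=O)O1`, gives 6.56%
compound 3, `C#CC[C@@H]1C[C@H](n2cccc2C(=O)CC)C(=O)O1`, gives 11.6%

Compound 3 carries the highest of the three numbers, but its lead is slight: the two steps that lead up to it are a number 3.6 percentage points higher from compound 1 to compound 3 (within the scatter) and a number 5 percentage points higher from compound 2 to compound 3 (within the scatter), both inside the scatter. Compound 1 and compound 2 differ by a number 1.5 percentage points lower from compound 1 to compound 2 (within the scatter), again inside the scatter. Across the three, the acyl group on the aromatic carbon has been absent, acetyl or propanoyl without a shift in this assay that can be trusted.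

Compound 4, `C#CC[C@@H]1C[C@H](n2cccc2C(=O)C(F)(F)F)C(=O)O1`, is the next member. Against compound 3 the change is trifluoromethyl in place of ethyl on a carbonyl carbon. The step that bears most directly on it is the change at the chain carbon bound to the carbonyl, from compound 1 to compound 3, which was within the scatter; the steps that remove or add the whole acyl group, from compound 1 to compound 2 and from compound 2 to compound 3, were also within the scatter. Nothing measured here suggests that swapping the ethyl for trifluoromethyl should move this assay by more than the usual spread. The step expected, a number 0.6 percentage points lower from compound 3 to compound 4 (within the scatter), is therefore none beyond the scatter. Compound 4 is expected to give 11%, with a range from 3% to 22%.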

Compound 4, a percentage reported as activity, at one concentration (the size of the read-out at that concentration, not a potency): 33.7%
Beside the measured number, compound 4's estimate is 22.7 percentage points below it; the measured number lies above the stated range.
By their numbers in this assay, from the lowest: compounds 2, 1 and 3 (each within the scatter of the next); then compound 4.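

In this assay, among the compounds shown here, the carbonyl carbon whose other neighbour is the aromatic carbon is the first place where a change stands clear of the scatter: the step with trifluoromethyl in place of ethyl is a number 22.1 percentage points higher from compound 3 to compound 4 (beyond the scatter) and the step with trifluoromethyl in place of methyl is a number 25.7 percentage points higher from compound 1 to compound 4 (beyond the scatter) even though methyl and ethyl at this place could not be told apart. Set against hydrogen on the aromatic carbon, the (trifluoromethyl)carbonyl group gives a number 27.1 percentage points higher from compound 2 to compound 4 (beyond the scatter) while acetyl and propanoyl both stayed within the scatter of hydrogen, so carrying an acyl group at this place is not enough for a rise, and what matters here is the group on the carbonyl carbon. Nothing available explains why the trifluoromethyl group stands apart.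

Still open, going by these compounds, is whether the rise needs all the fluorine of trifluoromethyl or would also appear with difluoromethyl, monofluoromethyl or a longer pentafluoroethyl chain on the same carbonyl carbon. With one tested concentration in this assay the size of the read-out also says nothing yet about potency across the series.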